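From 2,4-dibromophenyl to 4-methylphenyl on the amine nitrogen

A few compounds are considered here, and "the series" means these few. Any claim that something is new, unique, unknown or untested is made for them only; others in the source may bear on it.

For the measured compounds named here, in a functional assay, with a stated time of 6 min (a higher number here means a weaker inhibitor, a lower number a stronger inhibitor), compound 2 `S=c1oc(-c2ccc3c(c2)OCCO3)nn1CNc1ccc(Br)cc1Br` gives 6410 nM, the higher of the two numbers so far, while compound 1 `Fc1cc(NCn2nc(-c3ccc4c(c3)OCCO4)oc2=S)cc(F)c1F` gives 2920 nM. Compound 3 `Cc1ccc(NCn2nc(-c3ccc4c(c3)OCCO4)oc2=S)cc1` keeps the shared core and carries 4-methylphenyl in place of 2,4-dibromophenyl on an amine nitrogen. Going by the values given here, the only guide is the modest step of a 2.2-fold higher number from compound 1 to compound 2 (0.34 log units; beyond the scatter), which lies beyond the scatter and involves the same 2,4-dibromophenyl group. A similarly modest move to a lower number is therefore expected in this assay, and the estimated step is a 1.6-fold lower number from compound 2 to compound 3 (0.20 log units; within the scatter). The expected value for compound 3 is 4000 nM, with an estimated range of 1500 nM to 10000 nM.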

Compound 3, half-maximal inhibitory concentration: 5700 nM
Compound 3: middle estimate off by 1.4-fold (0.15 log units), on the low side, and the stated range covers the measured number.
By their numbers in this assay, from the lowest: compounds 1, 3 and 2 (each within the scatter of the next, the first and the last beyond it).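

In this assay the exchange of 2,4-dibromophenyl for 4-methylphenyl on the amine nitrogen leaves compound 2 and compound 3 inseparable (a 1.1-fold lower number from compound 2 to compound 3 (0.05 log units; within the scatter)). Compound 3 also cannot be separated from compound 1 (a 2.0-fold higher number from compound 1 to compound 3 (0.29 log units; within the scatter)), although compound 1 and compound 2 stand apart, so the methyl-bearing ring falls within the scatter of both halogen-bearing rings at this position. As far as these compounds go, it remains open whether a phenyl ring carrying a carboxylic acid or an amine would move the number further from these three. No measurement offered here explains the closeness of these numbers.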